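The source may hold more compounds than are shown below. What is called first, only, known or untested is meant among the compounds shown, and "the series" means these compounds.

In a functional assay on Jurkat cells (Homo sapiens) for inhibition, read by CCK-8 assay, with a stated time of 48 h (on this read-out higher numbers stand for weaker inhibition of growth and lower numbers for stronger inhibition of growth), compound 1 (`Cc1ccccc1Nc1nc(Nc2ccc(N3CCN(C)CC3)cn2)ncc1Cl`) gives 8080 nM. Compound 2 (`CN1CCN(c2ccc(Nc3ncc(Cl)c(Nc4ccccc4)n3)nc2)CC1`) returns only a limit, > 100000 nM. Compound 3 (`CN1CCN(c2ccc(Nc3ncc(Cl)c(NCc4ccc(F)cc4)n3)nc2)CC1`) also returns only a limit, > 100000 nM. It therefore stands at the limit of > 100000 nM in this assay, at which 2 of the 3 values shown sit, without a readable number.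

Compound 4 (`COc1cccc(CNc2nc(Nc3ccc(N4CCN(C)CC4)cn3)ncc2Cl)c1`) departs from compound 3 by one change, 3-methoxyphenyl in place of 4-fluorophenyl on a saturated chain carbon bound to a nitrogen on an aromatic ring.

Two measured steps show how much this part of the series can matter: an at least 12-fold higher number from compound 1 to compound 2 (1.09 log units; beyond the scatter) and an at least 12-fold higher number from compound 1 to compound 3 (1.09 log units; beyond the scatter). Both start from compound 1, and neither swaps one benzyl group for another. The closest comparison is a step that the two limits leave unreadable from compound 2 to compound 3, which gives no size to carry over. Compound 4 keeps a benzyl group like that of compound 3, which sits at > 100000 nM, so it is expected to stay near that limit.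

What is expected is a number no higher from compound 3 to compound 4 (the limit leaves the size open), with no clear direction. For compound 4 the estimate is 100000 nM, with an expected range of 30000 nM to 200000 nM.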

Compound 4, concentration for 50% growth inhibition: 73400 nM
Compound 4: the middle estimate sits 1.4-fold (0.13 log units) above what was measured, within the range that was stated.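

In this assay, 3-methoxyphenyl in place of 4-fluorophenyl on the saturated chain carbon yields a readable number for a benzyl compound, yet the change is not shown to exceed the scatter: the comparison gives an at least 1.3-fold lower number from compound 3 to compound 4 (0.13 log units; that floor lies within the scatter), and the comparison with the phenyl compound gives an at least 1.3-fold lower number from compound 2 to compound 4 (0.13 log units; that floor lies within the scatter). The 2-methylphenyl group of compound 1 still gives the strongest growth inhibition of the four, with a 9.1-fold higher number from compound 1 to compound 4 (0.96 log units; beyond the scatter). Both floors rest on a limit and not on a number: the limit of > 100000 nM in this assay, at which 2 of the 4 values shown sit.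

The compounds shown leave open whether the methoxy group or its ring position matters, which 3-fluorophenyl or 4-methoxyphenyl could separate. They also leave open whether a longer chain, or an amine on the ring, would bring the value nearer that of compound 1.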